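Amide substituent variation in an antiproliferative series

The source may hold more compounds than are shown below. What is called first, only, known or untested is meant among the compounds shown, and "the series" means these compounds.

Compound 3 `CCn1c(C(=O)NCCNC(=O)OC(C)(C)C)ccc1C(CC)(CC)c1ccc(OCS(=O)(=O)c2ccccc2)c(C)c1` is read in a functional assay on MCF7 cells (Homo sapiens) for antiproliferative activity, read by MTT assay, with a stated time of 24 h (a higher number here means a weaker inhibitor, a lower number a stronger inhibitor), only as a limit, > 50000 nM. Compound 1 `CCn1c(C(=O)N[C@H](C)C(=O)OC)ccc1C(CC)(CC)c1ccc(OCS(=O)(=O)c2ccccc2)c(C)c1` also gives only a limit in this assay, > 50000 nM. Compound 2 `CCn1c(C(=O)N[C@@H](CC(=O)OC)C(=O)OC)ccc1C(CC)(CC)c1ccc(OCS(=O)(=O)c2ccccc2)c(C)c1` likewise gives only a limit, > 50000 nM. Each measured step between them is accordingly unreadable: a step that the two limits leave unreadable from compound 1 to compound 2, a step that the two limits leave unreadable from compound 1 to compound 3 and a step that the two limits leave unreadable from compound 2 to compound 3, and the limit of > 50000 nM in this assay, at which 3 of the 3 values shown sit, sums up the position of the whole measured set.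

Compound 4 `CCn1c(C(=O)NCCCO)ccc1C(CC)(CC)c1ccc(OCS(=O)(=O)c2ccccc2)c(C)c1` has not been measured. Relative to compound 3 the change is hydroxymethyl in place of (tert-butoxycarbonyl)amino on a saturated chain carbon, two bonds along the chain from an amide-type nitrogen. Going by the values given here, no measured step bears on it in a readable way, since the only known steps are the ones above, each without a size; no direction beyond the scatter can be derived for this assay. None of the amide substituents tried so far has brought the number under the limit, and the cases at hand give no reason to expect hydroxymethyl in place of (tert-butoxycarbonyl)amino to do so. Compound 4 is therefore expected to sit at or beyond the limit as well, with an estimated 60000 nM (20000 nM to 200000 nM). The step this estimate means, a step that the limit leaves unreadable from compound 3 to compound 4, is expected to be small or itself unreadable.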

Compound 4, half-maximal inhibitory concentration: 42000 nM
Beside the measured number, compound 4's estimate is 1.4-fold (0.15 log units) above it; low and high end bracket the measured number.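

In this assay compound 4, with 3-hydroxypropyl on the amide-type nitrogen, is the only compound shown that gives a number rather than a limit, so this position can carry a readable value within the series. The change reads as an at least 1.1-fold lower number from compound 3 to compound 4 (0.07 log units; that floor lies within the scatter), as an at least 1.1-fold lower number from compound 2 to compound 4 (0.07 log units; that floor lies within the scatter) and as an at least 1.1-fold lower number from compound 1 to compound 4 (0.07 log units; that floor lies within the scatter); each of these is only a floor, so the real size of each step stays undetermined and no gain beyond the scatter is established. The other three compounds remain at the limit, and the steps among compound 1, compound 2 and compound 3 cannot be read: the limit of > 50000 nM in this assay, at which 3 of the 4 values shown sit.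

Still open, as far as these compounds go, is whether the number for compound 4 reflects a real separation from the rest of the set, or whether the series simply lies close to the limit. From the compounds shown here alone, it is also open how a 4-hydroxybutyl group, a primary amine or a carboxylic acid in place of 3-hydroxypropyl on the amide-type nitrogen would read in this assay.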